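The source may hold more compounds than are shown below. What is called first, only, known or untested is meant among the compounds shown, and "the series" means these compounds.

Compound 2 `Cc1ccccc1Oc1cccc(COc2ccccc2CCC(=O)OCCCOP(=O)(O)OC[C@H](N)C(=O)O)c1` is one of two compounds measured in an assay on cells for agonist activity at probable G-protein coupled receptor 34 (Mus musculus), with a stated time of 1 h; on this read-out lower numbers stand for smaller maximal responses and higher numbers for larger maximal responses; compound 2 gives 20.3%, the higher of the two numbers shown, while compound 1 `N[C@@H](COP(=O)(O)OCCCOC(=O)CCc1ccccc1OCc1cccc(OC2CCCCC2)c1)C(=O)O` gives 18.8%. For the measured compounds named here, the only measured step, a number 1.5 percentage points higher from compound 1 to compound 2 (within the scatter), exchanges a group on an oxygen and stays within the scatter. Compound 3 `N[C@@H](COP(=O)(O)OCCCOC(=O)CCc1ccccc1OCc1cccc(Oc2ccccc2Cl)c1)C(=O)O` differs from compound 2 by chloro in place of methyl on an aromatic carbon. Going by the values given here, no measured step swaps chloro for methyl, so there is no direct guide. Given that the one step, a number 1.5 percentage points higher from compound 1 to compound 2 (within the scatter), stayed within the scatter, no change beyond the scatter is expected, a number 0.3 percentage points lower from compound 2 to compound 3 (within the scatter). Compound 3 is therefore estimated at 20%, between 8% and 34%.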

Compound 3, largest response reached (Emax), in percent of the reference or control that the assay uses: 19.8%
The estimate for compound 3 lay 0.2 percentage points above the measured number; the measured number falls inside the stated range.
By their numbers in this assay, from the lowest: compounds 1, 3 and 2 (each within the scatter of the next).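

Swapping methyl for chloro on the aromatic carbon ortho to a large group leaves the response in this assay essentially unchanged (a number 0.5 percentage points lower from compound 2 to compound 3 (within the scatter)). On the oxygen, 2-chlorophenyl likewise stands level with cyclohexyl (a number 1 percentage points higher from compound 1 to compound 3 (within the scatter)), so all three compounds lie within the scatter of one another. Nothing available explains this sameness.

Still open, on these data alone, is whether an amine or a carboxylic acid at this ring position would move the response beyond the scatter. A longer chain there remains equally uncharted.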